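Swapping an aryl ring on the hydrazone of compound 3

The compounds below may be only part of what the source reports. "The series", "measured", "known", "first", "only" and "open" are said of these compounds alone.

Measured compounds:
compound 1 `CN(C(=O)NC(=O)c1ccc(Cl)cc1Cl)c1nc(C(F)(F)F)c(C(=O)N/N=C/c2ccc(C(F)(F)F)cc2)s1` 12.4 ug/mL
compound 2 `CN(C(=O)NC(=O)c1c(F)cccc1F)c1nc(C(F)(F)F)c(C(=O)N/N=C/c2cccc(C(F)(F)F)c2)s1` 27.9 ug/mL
compound 3 `Cc1nc(N(C)C(=O)NC(=O)c2c(F)cccc2F)sc1C(=O)N/N=C/c1cccc(C(F)(F)F)c1` 31.6 ug/mL

In a functional assay on HepG2 cells (Homo sapiens) for inhibition, read by MTT assay, with a stated time of 72 h (a higher number here means a weaker inhibitor, a lower number a stronger inhibitor), compound 3 gives 31.6 ug/mL, at the high end of the three numbers shown. Compound 2 gives 27.9 ug/mL, and the step of a 1.1-fold higher number from compound 2 to compound 3 (0.05 log units; within the scatter) is within the scatter. Going by the values given here, compound 1 gives 12.4 ug/mL, which lies beyond the scatter from compound 3; compound 1 differs from compound 3 in more than one place, so no single step is drawn between them.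

Compound 4 `COc1ccc(/C=N/NC(=O)c2sc(N(C)C(=O)NC(=O)c3c(F)cccc3F)nc2C)cc1` differs from compound 3 in one place: 4-methoxyphenyl in place of 3-(trifluoromethyl)phenyl on a carbon with a double bond to nitrogen. Among the compounds with values here, no measured step touches this position. Within the data shown here, the one step that is measured, from compound 2 to compound 3, concerns a different part of the molecule and was within the scatter, so it offers no direction for the present change. With nothing to point either way, the expected step of a 1.1-fold lower number from compound 3 to compound 4 (0.02 log units; within the scatter) is none beyond the scatter, with a wide range to allow for the untested aryl change.

Compound 4 is therefore estimated to give 30 ug/mL in this assay, with a range from 12 ug/mL to 75 ug/mL.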

Compound 4, half-maximal inhibitory concentration: 22.7 ug/mL
Compound 4: middle estimate off by 1.3-fold (0.12 log units), on the high side, and the stated range covers the measured number.
By their numbers in this assay, from the lowest: compounds 1, 4, 2 and 3 (each within the scatter of the next, the first and the last beyond it).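

The aryl ring on the hydrazone is now the one place in this series where a measured step bears directly on the group itself, and in this assay replacing 3-(trifluoromethyl)phenyl with 4-methoxyphenyl gives a 1.4-fold lower number from compound 3 to compound 4 (0.14 log units; within the scatter). On the core shared by these two compounds, the position therefore accepts the loss of the trifluoromethyl group and the entry of a methoxy group, which brings a hydrogen-bond acceptor, without the read-out moving beyond the usual scatter; since the group and its place on the ring change together, this single pair cannot separate the two changes. No supporting measurement bears on why the read-out stays within the scatter for this change.

The compounds shown leave open whether a more different group, such as a dimethylamino group or a carboxylic acid on this ring, or a longer alkyl chain in place of the ring, would also stay within the scatter. They also leave open whether 4-methoxyphenyl would behave the same way on the trifluoromethyl-bearing core of compound 2.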